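The source may hold more compounds than are shown below. What is called first, only, known or untested is meant among the compounds shown, and "the series" means these compounds.

This piece follows one change in a small set of compounds tested in a functional assay on HL-60 cells (Homo sapiens) for inhibition, read by CCK-8 assay, with a stated time of 48 h; a higher number here means a weaker inhibitor, a lower number a stronger inhibitor. Compound 1 `O=C(NCCNS(=O)(=O)c1ccc(-c2ccccc2O[C@H]2CC[C@H](O)CC2)s1)Nc1cc(Cl)cc(Cl)c1` gives > 20000 nM, which is a limit of the assay and not a number. Compound 2 `COc1ccc(NC(=S)NCCNS(=O)(=O)c2sccc2-c2ccc(C)cc2Oc2ccc(O)c(O)c2)cc1` gives 4100 nM. Compound 3 `Cc1ccc(-c2ccsc2S(=O)(=O)NCCNC(=S)Nc2ccc([N+](=O)[O-])cc2)c(Oc2ccc(O)c(O)c2)c1` gives 2900 nM, the lowest of the two numbers shown, but the step of a 1.4-fold lower number from compound 2 to compound 3 (0.15 log units; within the scatter) lies within the scatter, so the two compounds cannot be ordered. Compound 4 `Cc1ccc(-c2ccsc2S(=O)(=O)NCCNC(=O)Nc2cccc([N+](=O)[O-])c2)c(Oc2ccc(O)c(O)c2)c1` has not been measured. It differs from compound 3 as follows: a group of 12 heavy atoms (7 carbon, 2 nitrogen, 3 oxygen; one six-membered aromatic ring of carbon only) in place of a group of 12 heavy atoms (7 carbon, 2 nitrogen, 2 oxygen, 1 sulfur; one six-membered aromatic ring of carbon only), on an amine nitrogen. Going by the values given here, no measured step concerns this kind of exchange on the amine nitrogen. Among the compounds with values here, the only measured step, a 1.4-fold lower number from compound 2 to compound 3 (0.15 log units; within the scatter), swaps a different group and stays within the scatter. Within the data shown here, compound 1 sits at the limit of > 20000 nM in this assay, at which 1 of the 3 values shown sits, and has a different core, so it offers no step to compare. Compound 4 is therefore expected to land close to compound 3. The expected step is a 1.4-fold higher number from compound 3 to compound 4 (0.14 log units; within the scatter), within scatter. The estimate for compound 4 is 4000 nM, with a range from 1500 nM to 12000 nM.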

Compound 4, half-maximal inhibitory concentration: 6000 nM
The estimate for compound 4 lay 1.5-fold (0.18 log units) below the measured number, and the stated range covers the measured number.
By their numbers in this assay, from the lowest: compounds 3, 2 and 4 (each within the scatter of the next, the first and the last beyond it). At a limit, above all of these: compound 1.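

In this assay, the exchange on this amine nitrogen gives the first step among these compounds that lies beyond the scatter, though a modest one (a 2.1-fold higher number from compound 3 to compound 4 (0.32 log units; beyond the scatter)). The other exchange at this place stays within the scatter (a 1.5-fold higher number from compound 2 to compound 4 (0.17 log units; within the scatter)), so those two compounds cannot be ordered, and compound 3 is separated only from compound 4. The (3-nitrophenyl)carbamoyl group has an oxygen where the group in compound 3 has a sulfur, but the two groups differ in more than that atom, and nothing measured here explains the step.

The compounds shown do not separate the part played by the sulfur from that played by the rest of the group. On these data alone, how an acetyl or methanesulfonyl group on this amine nitrogen would read also stays open.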